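This account rests on a few compounds, and the source may have more. Where it says the series, first, only, none or still open, it means among the compounds named here.

Series notes, cytotoxicity. All numbers below come from a functional assay on MCF7 cells (Homo sapiens) for cytotoxicity, read by ELISA, with a stated time of 4 days; on this read-out lower numbers stand for stronger inhibition and higher numbers for weaker inhibition.

Measured so far:
compound 1, `Clc1cccc(-c2cc(-c3ccoc3)cc(-c3ccc(Cl)s3)n2)c1`, gives 2920 nM
compound 2, `Clc1ccc(-c2cc(-c3ccoc3)cc(-c3ccc(Cl)s3)n2)cc1`, gives 2600 nM
compound 3, `Cc1ccsc1-c1cc(-c2ccc(Cl)o2)cc(-c2cccc(Cl)c2)n1`, gives 18800 nM

Compound 1 and compound 2 share a core and differ only by 4-chlorophenyl in place of 3-chlorophenyl on an aromatic carbon. That change gave a 1.1-fold lower number from compound 1 to compound 2 (0.05 log units; within the scatter), so the two values stand level in this assay. Compound 3 sits on a different core; the difference between the two cores is not broken down here. Compound 3 gives the highest number of the three, and its gap to both compound 1 and compound 2 is beyond the scatter, so it is the weakest of the measured set.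

Compound 4, `Cc1ccsc1-c1cc(-c2ccc(Cl)o2)cc(-c2ccc(Cl)cc2)n1`, has not been measured. It differs from compound 3 by 4-chlorophenyl in place of 3-chlorophenyl on an aromatic carbon. Going by the values given here, this is the same kind of change as the one from compound 1 to compound 2, but the surroundings differ: in compound 3 the place is meta to a 3-methylthiophen-2-yl group and meta to a 5-chlorofuran-2-yl group, whereas in compound 1 it is meta to a 5-chlorothiophen-2-yl group and meta to a furan-3-yl group.

Among the compounds with values here, with only one observation of this change, the expectation rests on compound 1 and compound 2, where the step was within the scatter, and on the starting value of compound 3. The step from compound 3 to compound 4 is expected to be a 1.1-fold lower number from compound 3 to compound 4 (0.04 log units; within the scatter) in this assay, essentially flat. Within the data shown here, compound 4 is therefore estimated at 17000 nM in this assay, with a likely range from 8000 nM to 40000 nM, the wider range reflecting that the core of compound 3 is not the one on which the change was observed.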

Compound 4, half-maximal inhibitory concentration: 15300 nM
For compound 4 the middle estimate is 1.1-fold (0.05 log units) above the measured one, within the range that was stated.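

Replacing 3-chlorophenyl with 4-chlorophenyl on the core of compound 3 gave a 1.2-fold lower number from compound 3 to compound 4 (0.09 log units; within the scatter) in this assay, so the two values stand level on this core as well. Set beside the earlier case, the change carries across the two cores without a detectable difference: the same change on two cores in this assay, a 1.1-fold lower number (0.05 log units; within the scatter) from compound 1 to compound 2 and a 1.2-fold lower number (0.09 log units; within the scatter) from compound 3 to compound 4, 1.1-fold (0.04 log units) apart, within the scatter of two such steps. This shows a flat step on two cores only, here with the place meta to a 3-methylthiophen-2-yl group and meta to a 5-chlorofuran-2-yl group; it does not show that the change stays flat on any other core, and it gives no explanation for the flatness.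

The compounds shown leave open what a different substituent on that phenyl ring would do, such as an amine, a carboxylic acid or a longer chain in place of the chlorine, and whether any such group would move the number beyond the scatter. They also leave open the separate contribution of each group that differs between the two cores, as no pair shown changes only one of those groups.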